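Tolerance limit and a 3-methoxyphenyl swap in the series

The source may report more compounds than this note shows. Statements on the series, on what has been measured and on what is new or still open speak of the compounds shown alone.

Measured in an ADME assay on HEK-293T cells (Homo sapiens) for cytotoxicity, read by MTT assay, with a stated time of 48 h (a lower number here means that less compound is tolerated, a higher number that more compound is tolerated), as half-maximal cytotoxic concentration:
- Compound 1 (`COc1ccc(C2=NN(C(=O)c3ccncc3)C(c3cn(C)c4ccc(Br)cc34)C2)cc1OC`): > 300000 nM (a limit)
- Compound 2 (`COc1ccc2c(c1)c(C1CC(c3ccc(Br)cc3)=NN1C(=O)c1ccc(OC)nc1)cn2C`): > 300000 nM (a limit)

Compound 2 stands at > 300000 nM as a limit of the assay and not a number. Within the data shown here, the two measured compounds share that position, and the series so far comes down to the limit of > 300000 nM in this assay, at which 2 of the 2 values shown sit, with no number to rank them. Among the measured compounds shown here, no step between measured compounds is available to size a change.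

Compound 3 (`COc1cccc(C2=NN(C(=O)c3ccc(OC)nc3)C(c3cn(C)c4ccc(OC)cc34)C2)c1`) differs from compound 2 in one place (3-methoxyphenyl in place of 4-bromophenyl on a carbon with a double bond to nitrogen): 3-methoxyphenyl in place of 4-bromophenyl on a carbon with a double bond to nitrogen.

No step beyond the scatter is expected in this assay for this change, and that expectation rests on compound 2 at > 300000 nM as a limit. The estimated move, a number no higher from compound 2 to compound 3 (the limit leaves the size open) in size, is expected to be small, and a report of only a limit is again the likeliest outcome. For compound 3 the expected value is 300000 nM as the middle estimate, with an estimated range from 80000 nM to 500000 nM for a single measurement.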

Compound 3, half-maximal cytotoxic concentration: > 300000 nM
Compound 3 ended at the assay's limit; the forecaster's own chance of this, stated with the estimate: 75%; the middle value sits exactly at the limit.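

Compound 3 gives > 300000 nM, a limit of the assay and not a number. No step can be read between compound 2 and compound 3, and the change to 3-methoxyphenyl stays unsized, with the series resting on one point: the limit of > 300000 nM in this assay, at which 3 of the 3 values shown sit. The compounds shown leave open at what concentration any of them reaches the half-maximal cytotoxic effect.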